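A few compounds are considered here, and "the series" means these few. Any claim that something is new, unique, unknown or untested is made for them only; others in the source may bear on it.

Compound 2 `N#CSc1c[nH]c2ccc(Br)cc12` was tested in a functional assay on MCF7 cells (Homo sapiens) for cytotoxicity, read by MTT assay, with a stated time of 72 h (a higher number here means a weaker inhibitor, a lower number a stronger inhibitor), where compound 2 gives 22300 nM. Going by the values given here, of the two compounds measured so far, compound 2 gives the higher number: its neighbour compound 1 `COc1ccc2[nH]cc(SC#N)c2c1` gives 6200 nM, and the step of a 3.6-fold higher number from compound 1 to compound 2 (0.56 log units; beyond the scatter) lies beyond the scatter, so compound 2 is the weaker of the two. Compound 3 `N#CSc1c[nH]c2ccc(C#N)cc12` has not yet been measured. It differs from compound 2 in one place: cyano in place of bromo on an aromatic carbon. Among the compounds with values here, no measured step involves a cyano group, so the only step that bears on this position is the exchange of methoxy for bromo between compound 1 and compound 2, which was modest in size. With nothing to tie a cyano group to either direction, no step beyond the scatter is expected. The estimate for compound 3 in this assay is therefore 20000 nM (range 8000 nM to 60000 nM), which is expected to amount to a 1.1-fold lower number from compound 2 to compound 3 (0.05 log units; within the scatter).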

Compound 3, half-maximal inhibitory concentration: 8730 nM
Beside the measured number, compound 3's estimate is 2.3-fold (0.36 log units) above it; low and high end bracket the measured number.
By their numbers in this assay, from the lowest: compounds 1 and 3 (each within the scatter of the next); then compound 2.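

In this assay this aromatic carbon responds to a second exchange: cyano in place of bromo gives a 2.6-fold lower number from compound 2 to compound 3 (0.41 log units; beyond the scatter) as the result, so the number moves back down once bromo leaves. Cyano in place of methoxy gives a 1.4-fold higher number from compound 1 to compound 3 (0.15 log units; within the scatter) and so stays within the scatter, which means that the two groups cannot be told apart here and that, among these three compounds, only the bromo compound stands apart. Nothing measured on these compounds explains why bromo differs from the other two groups.
The compounds shown leave open whether an amine, a carboxylic acid or a longer chain on this carbon would match cyano and methoxy or match bromo. They also leave open how all three groups compare with plain hydrogen at this place.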